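Amide aryl variation on the shared core

The source may hold more compounds than are shown below. What is called first, only, known or untested is meant among the compounds shown, and "the series" means these compounds.

In an assay on isolated protein for inhibition of histone deacetylase 8 (Homo sapiens), with a stated time of 1 h (a lower number here means a stronger inhibitor, a higher number a weaker inhibitor), compound 1 `Cc1ccc(NC(=O)COc2ccc3cc(/C=C4/SC(=O)NC4=O)ccc3c2)cc1` gives 9000 nM. Compound 2 `COc1cccc(NC(=O)COc2ccc3cc(/C=C4/SC(=O)NC4=O)ccc3c2)c1` gives 7600 nM, and compound 3 `Cc1cc(Br)ccc1NC(=O)COc1ccc2cc(/C=C3/SC(=O)NC3=O)ccc2c1` gives 7400 nM. Compound 2 stands second highest of the three numbers shown, with compound 3 nearest and compound 1 furthest, both gaps within the scatter. Compound 4 `O=C(COc1ccc2cc(/C=C3/SC(=O)NC3=O)ccc2c1)Nc1cc(Cl)cc(C(F)(F)F)c1` differs from compound 2 by 3-chloro-5-(trifluoromethyl)phenyl in place of 3-methoxyphenyl on an amide-type nitrogen. The measured steps that bear on this are the earlier aryl changes on the amide-type nitrogen: a 1.2-fold lower number from compound 1 to compound 2 (0.07 log units; within the scatter), a 1.2-fold lower number from compound 1 to compound 3 (0.09 log units; within the scatter) and a 1.0-fold lower number from compound 2 to compound 3 (0.01 log units; within the scatter), none beyond the scatter. A step of no more than the scatter is therefore expected here, a 1.0-fold lower number from compound 2 to compound 4 (0.01 log units; within the scatter), in no firm direction. Compound 4 is expected to give 7500 nM, within 3500 nM to 16000 nM.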

Compound 4, half-maximal inhibitory concentration: > 50000 nM
Compound 4 ended at the assay's limit (the forecaster's own chance of this, stated with the estimate: 5%); at least 6.6-fold (0.82 log units) between middle value and limit.
By their numbers in this assay, from the lowest: compounds 3, 2 and 1 (each within the scatter of the next). At a limit, above all of these: compound 4.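

Compound 4 ends at a limit of this assay, not at a number: the limit of > 50000 nM in this assay, at which 1 of the 4 values shown sits.

The aryl group on the amide-type nitrogen is therefore not freely interchangeable: 3-chloro-5-(trifluoromethyl)phenyl brings an at least 6.5-fold higher number from compound 2 to compound 4 (0.81 log units; beyond the scatter), an at least 6.7-fold higher number from compound 3 to compound 4 (0.82 log units; beyond the scatter) and an at least 5.5-fold higher number from compound 1 to compound 4 (0.74 log units; beyond the scatter), whereas the three earlier aryl groups stayed within the scatter of one another.

As far as these compounds go, the true size of these steps remains open, as does whether the chlorine or the trifluoromethyl group alone accounts for them. Also open, from the compounds shown here alone, is whether an aryl group carrying an amine or a carboxylic acid would give a number clearly lower than those of compounds 1, 2 and 3.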